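This account rests on a few compounds, and the source may have more. Where it says the series, first, only, none or still open, it means among the compounds named here.

Measured compounds:
compound 1 `O=S(=O)(Oc1ccc(F)cc1)C1CC2OC1C(c1ccc(/C=C/c3cc(O)cc(O)c3)cc1)=C2c1ccc(O)cc1` — 13100 nM
compound 2 `O=S(=O)(Oc1ccccc1C(F)(F)F)C1CC2OC1C(c1ccc(/C=C/c3cc(O)cc(O)c3)cc1)=C2c1ccc(O)cc1` — 18300 nM
compound 3 `Cc1cccc(OS(=O)(=O)C2CC3OC2C(c2ccc(/C=C/c4cc(O)cc(O)c4)cc2)=C3c2ccc(O)cc2)c1` — 16300 nM

In a functional assay on MCF7 cells (Homo sapiens) for antiproliferative activity, read by MTT assay, with a stated time of 72 h (on this read-out lower numbers stand for stronger inhibition and higher numbers for weaker inhibition), the three values sit close together. Compound 3 stands second highest of the three numbers, separated from its nearest neighbour by a 1.1-fold lower number from compound 2 to compound 3 (0.05 log units; within the scatter) and from the furthest by a 1.2-fold higher number from compound 1 to compound 3 (0.09 log units; within the scatter), both within the scatter.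

Compound 4 `O=S(=O)(Oc1cccc2ccccc12)C1CC2OC1C(c1ccc(/C=C/c3cc(O)cc(O)c3)cc1)=C2c1ccc(O)cc1` differs from compound 3 by naphthalen-1-yl in place of 3-methylphenyl on an oxygen. All three measured steps change the aryl group on this same oxygen: a 1.4-fold higher number from compound 1 to compound 2 (0.15 log units; within the scatter), a 1.2-fold higher number from compound 1 to compound 3 (0.09 log units; within the scatter) and a 1.1-fold lower number from compound 2 to compound 3 (0.05 log units; within the scatter), none reaching beyond the scatter. No listed step involves a second aromatic ring at this position, so the bearing is indirect. The expectation for compound 4 is therefore no step beyond the scatter, a 1.0-fold lower number from compound 3 to compound 4 (0.01 log units; within the scatter). Compound 4 is estimated at 16000 nM, within 7000 nM to 36000 nM.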

Compound 4, half-maximal inhibitory concentration: 11000 nM
Beside the measured number, compound 4's estimate is 1.5-fold (0.16 log units) above it, and the stated range covers the measured number.
By their numbers in this assay, from the lowest: compounds 4, 1, 3 and 2 (each within the scatter of the next).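

In this assay, adding a second aromatic ring on this oxygen gives no step beyond the scatter: a 1.5-fold lower number from compound 3 to compound 4 (0.17 log units; within the scatter), a 1.7-fold lower number from compound 2 to compound 4 (0.22 log units; within the scatter) and a 1.2-fold lower number from compound 1 to compound 4 (0.08 log units; within the scatter). The position therefore accepts naphthalen-1-yl as well as the single-ring aryl groups, with no separation among the four compounds. No available data bear on why these values stay so close.

Still open, on these data alone, is whether an aryl ring carrying an amine or a carboxylic acid, or a longer alkyl chain in place of the aryl group on this oxygen, would give a step beyond the scatter.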